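Sulfamide series: methoxy in place of butyl on the aryl ring

The source may hold more compounds than are shown below. What is called first, only, known or untested is meant among the compounds shown, and "the series" means these compounds.

Three members of the series carry numbers in a functional assay on M21 cells (Homo sapiens) for antiproliferative activity, read by sulforhodamine B assay, with a stated time of 48 h; a lower number here means a stronger inhibitor of growth, a higher number a weaker inhibitor of growth. Compound 1 `COc1ccc(-c2cc(N3CCC(CNS(N)(=O)=O)CC3)ncn2)cc1`, which bears the methoxy group together with a shorter chain to the sulfamide, reports only a limit, > 100000 nM, and stands at the limit of > 100000 nM in this assay, at which 1 of the 3 values shown sits. Compound 2 `Cc1ccc(-c2cc(N3CCC(CCNS(N)(=O)=O)CC3)ncn2)cc1` gives 57600 nM in this assay. Compound 3 `CCCCc1ccc(-c2cc(N3CCC(CCNS(N)(=O)=O)CC3)ncn2)cc1` gives 15100 nM in this assay, the lowest of the two numbers, and the step of a 3.8-fold lower number from compound 2 to compound 3 (0.58 log units; beyond the scatter) is the only one measured within this set.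

Compound 4 `COc1ccc(-c2cc(N3CCC(CCNS(N)(=O)=O)CC3)ncn2)cc1` keeps the longer chain of compound 3 and differs from it by methoxy in place of butyl on an aromatic carbon. Going by the values given here, the single relevant comparison is a 3.8-fold lower number from compound 2 to compound 3 (0.58 log units; beyond the scatter), in which a longer alkyl group gave the lower number; removing the butyl group for a smaller group is therefore expected to move the number back upward, by a modest amount rather than beyond the range spanned by compound 2 and compound 3. The estimated value for compound 4 is 60000 nM, with a range from 20000 nM to 180000 nM. This estimate corresponds to an expected step of a 4.0-fold higher number from compound 3 to compound 4 (0.60 log units; beyond the scatter).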

Compound 4, concentration for 50% growth inhibition: 69800 nM
Compound 4: middle estimate off by 1.2-fold (0.07 log units), on the low side, within the range that was stated.
By their numbers in this assay, from the lowest: compound 3; then compounds 2 and 4 (each within the scatter of the next). At a limit, above all of these: compound 1.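

In this assay methoxy on the aromatic carbon para to a large group shows a 4.6-fold higher number from compound 3 to compound 4 (0.66 log units; beyond the scatter) and a 1.2-fold higher number from compound 2 to compound 4 (0.08 log units; within the scatter) so in this set butyl alone sets itself apart, while methoxy and methyl cannot be told apart. Going by these compounds alone, for the chain to the sulfamide the only reading is an at least 1.4-fold lower number from compound 1 to compound 4 (0.15 log units; that floor lies within the scatter) and that reading does not establish a difference beyond the scatter. Compound 1 stands at a limit, not at a number: the limit of > 100000 nM in this assay, at which 1 of the 4 values shown sits.

As far as these compounds go, whether a chain longer than butyl, such as hexyl, would carry the number lower at this place remains open. Also open, from the compounds shown here alone, is how an amine or a carboxylic acid would read there, and whether any gain at this place would hold with the shorter chain to the sulfamide.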